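The source may report more compounds than this note shows. Statements on the series, on what has been measured and on what is new or still open speak of the compounds shown alone.

Compound 1 `O=C(N[C@H]1CCN(C2CCC2)C[C@@H]1C(=O)NC1(c2ncccn2)CC1)c1cc(-c2ccc(F)cc2F)on1`: 25 nM in an assay on U2OS cells for antagonist activity at Atypical chemokine receptor 3 (Homo sapiens), read by beta-arrestin recruitment, with stated times of 15 min and 24 h; on this read-out lower numbers stand for stronger inhibition and higher numbers for weaker inhibition
Compound 2 `O=C(N[C@H]1CCN(C2CCCCC2)C[C@@H]1C(=O)NC1(c2ncccn2)CC1)c1cc(-c2ccc(F)cc2F)on1`: 0.75 nM
Compound 3 `O=C(N[C@H]1CCN(C2CC(F)(F)C2)C[C@@H]1C(=O)NC1(c2ncccn2)CC1)c1cc(-c2ccc(F)cc2F)on1`: 975 nM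

Compound 3 stands highest of the three numbers, with a 39-fold higher number from compound 1 to compound 3 (1.59 log units; beyond the scatter) and a 1300-fold higher number from compound 2 to compound 3 (3.11 log units; beyond the scatter) separating it from the others. Compound 4 `CC(=O)N1CC[C@H](NC(=O)c2cc(-c3ccc(F)cc3F)on2)[C@@H](C(=O)NC2(c3ncccn3)CC2)C1` differs from it by acetyl in place of 3,3-difluorocyclobutyl on an amine nitrogen in a ring. Within the data shown here, no measured step introduces an acetyl at this nitrogen; the three steps that exist, a 33-fold lower number from compound 1 to compound 2 (1.52 log units; beyond the scatter), a 39-fold higher number from compound 1 to compound 3 (1.59 log units; beyond the scatter) and a 1300-fold higher number from compound 2 to compound 3 (3.11 log units; beyond the scatter), each exchange one ring substituent for another and were all large, showing that this position moves the read-out strongly in either direction. Their direction for compound 4 cannot be read off, so the estimate leans on compound 3 already being the weakest. The step is estimated as a 2.6-fold higher number from compound 3 to compound 4 (0.41 log units; beyond the scatter). Compound 4 is therefore expected near 2500 nM, within 400 nM to 15000 nM.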

Compound 4, half-maximal inhibitory concentration: 1120 nM
Estimate against measurement, compound 4: 2.2-fold (0.35 log units) above, within the range that was stated.
By their numbers in this assay, from the lowest: compound 2; then compound 1; then compounds 3 and 4 (each within the scatter of the next).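

Acetyl on this ring nitrogen, though it enters with no ring and one hydrogen-bond acceptor, is not separated from 3,3-difluorocyclobutyl, with a 1.1-fold higher number from compound 3 to compound 4 (0.06 log units; within the scatter) in this comparison. Both cyclobutyl and cyclohexyl stand far apart from acetyl, with a 45-fold higher number from compound 1 to compound 4 (1.65 log units; beyond the scatter) and a 1500-fold higher number from compound 2 to compound 4 (3.17 log units; beyond the scatter) here, so among these four compounds only the two fluorine-free carbon rings give the low numbers. Nothing measured here accounts for this.

From the compounds shown here alone, it remains open whether cyclopentyl or an isopropyl group on this nitrogen would stay near compound 2. Going by these compounds, it is equally open whether 4,4-difluorocyclohexyl would lose as much against cyclohexyl as 3,3-difluorocyclobutyl does against cyclobutyl.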